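Changing the Aryl Group on the Amide Nitrogen

The compounds below may be only part of what the source reports. "The series", "measured", "known", "first", "only" and "open" are said of these compounds alone.

Three compounds have been measured in an assay on isolated protein for inhibition of histone deacetylase 4 (Homo sapiens), with a stated time of 1 h; on this read-out higher numbers stand for weaker inhibition and lower numbers for stronger inhibition:

compound 1, `Cc1ccc(NC(=O)COc2ccc3cc(/C=C4/SC(=O)NC4=O)ccc3c2)cc1Cl`, gives 1100 nM
compound 2, `O=C(COc1ccc2cc(/C=C3/SC(=O)NC3=O)ccc2c1)Nc1ccc(Br)cc1`, gives 2900 nM
compound 3, `O=C(COc1ccc2cc(/C=C3/SC(=O)NC3=O)ccc2c1)Nc1ccccn1`, gives 17000 nM

All three share the same core and differ only in the aryl group attached to the amide-type nitrogen. Compound 3 stands at the highest number of the three, which on this assay means the weakest inhibition: the step was a 5.9-fold higher number from compound 2 to compound 3 (0.77 log units; beyond the scatter) and a 15-fold higher number from compound 1 to compound 3 (1.19 log units; beyond the scatter), both beyond the scatter. Compound 4, `O=C(COc1ccc2cc(/C=C3/SC(=O)NC3=O)ccc2c1)Nc1ccc(F)cc1F`, has not yet been measured. The change from compound 3 is 2,4-difluorophenyl in place of pyridin-2-yl on an amide-type nitrogen. The two steps that bear on it are those leading into compound 3, since both replaced a carbon-only aromatic ring bearing halogen with the pyridin-2-yl group and both raised the number, by a modest and by a large amount. Reversing that kind of change, back to a halogen-bearing carbon-only ring, is expected to lower the number again, probably toward the region where compound 2 and compound 1 sit. The expected step is therefore a 4.9-fold lower number from compound 3 to compound 4 (0.69 log units; beyond the scatter). For compound 4 the estimated value is 3500 nM, with a range from 1200 nM to 10000 nM.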

Compound 4, half-maximal inhibitory concentration: 3900 nM
Compound 4: middle estimate off by 1.1-fold (0.05 log units), on the low side, and the stated range covers the measured number.
By their numbers in this assay, from the lowest: compound 1; then compounds 2 and 4 (each within the scatter of the next); then compound 3.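

In this assay, putting 2,4-difluorophenyl in place of pyridin-2-yl on the amide-type nitrogen gives a 4.4-fold lower number from compound 3 to compound 4 (0.64 log units; beyond the scatter) and so adds a third halogen-bearing, carbon-only ring that reads lower than pyridin-2-yl, with no compound shown going against this. A new point is that the particular halogens do not always separate such rings: the comparison with 4-bromophenyl is a 1.3-fold higher number from compound 2 to compound 4 (0.13 log units; within the scatter) and so gives no order between these two groups. The 3-chloro-4-methylphenyl group still stands apart, with a 3.5-fold higher number from compound 1 to compound 4 (0.55 log units; beyond the scatter) showing that compound 1 keeps the lowest number and the strongest inhibition of the four, although that ring differs from the others in both its halogen and its methyl group.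

Nothing at hand explains why these aryl groups give different numbers. The compounds shown leave open what a plain phenyl ring would give, which would help separate the ring nitrogen of pyridin-2-yl from the absence of halogen, and how a pyridin-2-yl ring bearing a chlorine or a phenyl ring bearing an amine or a carboxylic acid would read.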